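Swapping the aryl group on the ring nitrogen of compound 1

A few compounds are considered here, and "the series" means these few. Any claim that something is new, unique, unknown or untested is made for them only; others in the source may bear on it.

Measured so far:
- compound 1, `C=C(C)c1cccc(N2CCN(C(=O)c3oc(C)nc3-c3ccccc3F)CC2)c1`: "not active" (no number reported)
- compound 2, `Cc1nc(-c2ccc(F)cc2)c(C(=O)N2CCN(c3ccc(C(=O)C(C)C)cc3)CC2)o1`: "not active" (no number reported)
- compound 3, `CCc1nc(-c2ccccc2F)c(C(=O)N2CCN(c3cccc(Cl)c3)CC2)o1`: 139 nM

In a functional assay on HL-60 cells (Homo sapiens) for inhibition, read by MTT assay, with a stated time of 72 h (a higher number here means a weaker inhibitor, a lower number a stronger inhibitor), compound 1 gives "not active" (no number reported), with no number behind it, so it stands apart from compound 3, which gives 139 nM in this assay. Compound 2 likewise gives "not active" (no number reported) in this assay. Within the data shown here, compound 1 and compound 3 differ in more than one place, so their values show only that one carries a number and the other does not.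

Compound 4, `Cc1nc(-c2ccccc2F)c(C(=O)N2CCN(c3cc(Cl)ccc3C)CC2)o1`, is not yet measured. It differs from compound 1 in one place: 5-chloro-2-methylphenyl in place of 3-(1-methylethenyl)phenyl on an amine nitrogen in a ring. Among the measured compounds shown here, no pair of measured compounds differs in one place, so no step within the set can be used here. The change brings compound 4 nearer in shape to compound 3, which carries a number. A step toward a stronger inhibitor is expected, beyond the scatter, but with wide uncertainty. Compound 4 is expected to give about 500 nM in this assay, within the range 100 nM to 5000 nM.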

Compound 4, half-maximal inhibitory concentration: 229 nM
Compound 4: the middle estimate sits 2.2-fold (0.34 log units) above what was measured; low and high end bracket the measured number.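

In this assay, among these compounds, compound 4 gives 229 nM while compound 1 gives "not active" (no number reported) without a number, so no step between compound 1 and compound 4 can be read. The compounds shown leave open how large that change is and what lies behind it, and no measurement here speaks to a cause.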